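The source may hold more compounds than are shown below. What is called first, only, known or untested is meant among the compounds shown, and "the series" means these compounds.

Compound 3, `Cc1nc(-c2ccc(F)cc2)sc1COc1ccc2c(c1)OCC2CC(=O)O`, belongs to a small set of compounds that share one core and differ only in the aromatic group attached to it. In a functional assay on CHO cells for agonist activity at Free fatty acid receptor 1 (Homo sapiens), read by FLIPR and calcium flux (on this read-out lower numbers stand for an effect already at smaller amounts and higher numbers for an effect only at larger amounts of compound), compound 3 gives 48.7 nM, the lowest of the two numbers measured, and compound 1, `Cc1nc(-c2ccsc2)sc1COc1ccc2c(c1)OCC2CC(=O)O`, gives 68.5 nM. Among the compounds with values here, the only single change among the measured compounds is a 1.4-fold lower number from compound 1 to compound 3 (0.15 log units; within the scatter), which replaces thiophen-3-yl with 4-fluorophenyl and leaves the result within the scatter. Compound 2, `Cc1nc(-c2ccc(Cl)s2)sc1COc1ccc2c(c1)OCC2CC(=O)O`, carries a chlorinated thiophene; in this assay compound 2 gives "not determined" (no result reported), so no number is available for it.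

Compound 4, `Cc1nc(-c2ccc(C(F)(F)F)cc2)sc1COc1ccc2c(c1)OCC2CC(=O)O`, is the next step from compound 3. The change is trifluoromethyl in place of fluoro on an aromatic carbon: the fluoro leaves and a trifluoromethyl enters, on an aromatic carbon of a six-membered aromatic ring of carbon only, para to a large group. Within the data shown here, no measured step touches this exact exchange; the only comparison available shows that swapping the whole aromatic group between compound 1 and compound 3 moved the number very little. On that basis, compound 4 is expected to stay close to compound 3, with a step of a 1.1-fold higher number from compound 3 to compound 4 (0.05 log units; within the scatter) and no clear direction beyond the scatter. The estimate for compound 4 in this assay is 55 nM, with a range from 20 nM to 160 nM.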

Compound 4, half-maximal effective concentration: 96.7 nM
Compound 4: the middle estimate sits 1.8-fold (0.25 log units) below what was measured; the range from low to high includes it.
By their numbers in this assay, from the lowest: compounds 3, 1 and 4 (each within the scatter of the next).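

In this assay, within the data shown here, the exchange of fluoro for trifluoromethyl on an aromatic carbon, para to a large group, gives a 2.0-fold higher number from compound 3 to compound 4 (0.30 log units; within the scatter), the first reading of a change made at this exact place on the ring, and it does not leave the scatter of repeated measurements. Exchanging the whole aromatic group, with 4-(trifluoromethyl)phenyl in place of thiophen-3-yl, gives a 1.4-fold higher number from compound 1 to compound 4 (0.15 log units; within the scatter), which is also within the scatter, so the three measured compounds cannot be told apart and this position has so far accepted a single fluoro, a larger trifluoromethyl and a different aromatic ring with no step beyond the scatter. No measurement is at hand that could account for these numbers.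

As far as these compounds go, whether an amine, a methoxy group or a longer chain such as butyl on this same aromatic carbon would give a step beyond the scatter remains open. The compounds shown also all keep the shared core unchanged, so they say nothing about how sensitive the number is to a change anywhere else in the structure.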